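This account rests on a few compounds, and the source may have more. Where it says the series, first, only, none or still open, it means among the compounds named here.

Measured in an ADME assay on SH-SY5Y cells (Homo sapiens) for cytotoxicity, read by MTT assay, with a stated time of 72 h; on this read-out lower numbers stand for stronger inhibition and higher numbers for weaker inhibition:
Compound 1 `O=C(CN1CCN(C(=O)c2ccc(Cl)cc2)CC1)N1CCN(CCCc2c[nH]c3ccccc23)CC1`: 139000 nM
Compound 2 `COc1ccc2[nH]cc(CCCN3CCN(C(=O)CN4CCN(C(=O)c5ccc(Cl)cc5)CC4)CC3)c2c1`: 159000 nM

Within the data shown here, compound 2, at 159000 nM, lies within the scatter of compound 1, the only other compound measured. Compound 3 `COc1cccc(C(=O)N2CCN(CC(=O)N3CCN(CCCc4c[nH]c5ccc(OC)cc45)CC3)CC2)c1` differs from compound 2 by 3-methoxyphenyl in place of 4-chlorophenyl on a carbonyl carbon. Among the measured compounds shown here, the one measured step, a 1.1-fold higher number from compound 1 to compound 2 (0.06 log units; within the scatter), is methoxy in place of hydrogen on an aromatic carbon, so it bears only loosely on this change. For the measured compounds named here, no measured step tests this exchange directly. In this assay, no shift beyond the scatter is therefore expected, in either direction. The estimated step is a 1.1-fold lower number from compound 2 to compound 3 (0.03 log units; within the scatter). Compound 3 is expected at 150000 nM, within an estimated range of 70000 nM to 320000 nM.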

Compound 3, half-maximal inhibitory concentration: > 200000 nM
Compound 3: only a limit was reported (the forecaster's own chance of this, stated with the estimate: 10%); middle value at least 1.3-fold (0.12 log units) from the limit.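

In this assay, compound 3 gives > 200000 nM, which is a limit and not a number. Going by these compounds, replacing 4-chlorophenyl with 3-methoxyphenyl on this carbonyl carbon gives an at least 1.2-fold higher number from compound 2 to compound 3 (0.09 log units; that floor lies within the scatter), so this change at this position does not clearly separate the two compounds, and the full size of the step remains unknown. This reading rests on a limit: the limit of > 200000 nM in this assay, at which 1 of the 3 values shown sits.

The compounds shown leave open whether the chlorine and the methoxy matter separately. On these data alone, it is also open how an unsubstituted phenyl or a phenyl bearing a carboxylic acid on this carbonyl carbon would read.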